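A Longer Phenoxy Chain in a Level Series

This account rests on a few compounds, and the source may have more. Where it says the series, first, only, none or still open, it means among the compounds named here.

In a functional assay on HepG2 cells (Homo sapiens) for antiproliferative activity, read by MTT assay, with a stated time of 48 h (a higher number here means a weaker inhibitor of growth, a lower number a stronger inhibitor of growth), compound 1 (`CCCCCN(Cc1ccc(C(=O)NO)cc1)c1ncc(-c2ccc(C)cc2)s1`) gives 7020 nM, compound 2 (`Cc1ccc(-c2cnc(N(Cc3ccc(C(=O)NO)cc3)CC(C)C)s2)cc1`) gives 7420 nM and compound 3 (`Cc1ccc(OCCCN(Cc2ccc(C(=O)NO)cc2)c2ncc(-c3ccc(C)cc3)s2)cc1`) gives 12200 nM. For the measured compounds named here, compound 2 therefore sits among values that no step separates beyond the scatter, as a 1.1-fold higher number from compound 1 to compound 2 (0.02 log units; within the scatter) and a 1.6-fold higher number from compound 2 to compound 3 (0.22 log units; within the scatter) show.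

Compound 4 (`Cc1ccc(OCCCCN(Cc2ccc(C(=O)NO)cc2)c2ncc(-c3ccc(C)cc3)s2)cc1`) has not yet been measured. It carries 3-(4-methylphenoxy)propyl in place of isopropyl on a saturated chain carbon bound to a nitrogen on an aromatic ring.

The closest evidence is the step to compound 3, which brings 2-(4-methylphenoxy)ethyl onto the same carbon. That step, a 1.6-fold higher number from compound 2 to compound 3 (0.22 log units; within the scatter), stays within the scatter, as does a 1.7-fold higher number from compound 1 to compound 3 (0.24 log units; within the scatter). The data therefore give no reason to expect a large change in this assay. The expected result is a 1.5-fold higher number from compound 2 to compound 4 (0.17 log units; within the scatter), a small move toward a higher number that would remain within the scatter. For compound 4 the estimated value is 11000 nM, with an expected range from 5500 nM to 22000 nM.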

Compound 4, concentration for 50% growth inhibition: 11000 nM
Beside the measured number, compound 4's estimate shows no gap at the digits printed, within the range that was stated.
By their numbers in this assay, from the lowest: compounds 1, 2, 4 and 3 (each within the scatter of the next).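

In this assay, the place on a saturated chain carbon bound to a nitrogen on an aromatic ring also accepts 3-(4-methylphenoxy)propyl, with a 1.5-fold higher number from compound 2 to compound 4 (0.17 log units; within the scatter) as the step from isopropyl, so this group of 11 heavy atoms leaves the reading level. Extending the chain that carries the 4-methylphenoxy group gives a 1.1-fold lower number from compound 3 to compound 4 (0.04 log units; within the scatter) and so separates nothing, while a 1.6-fold higher number from compound 1 to compound 4 (0.20 log units; within the scatter) shows that this compound also stays level with the plain alkyl chain of compound 1.

Still open, as far as these compounds go, is whether a chain ending in an amine or a carboxylic acid, in place of 4-methylphenoxy, would stay as level as these four compounds. No measurement at hand explains why these chains read alike.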